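Bromo in Place of Nitro on a Shared Oxindole-Type Core

This account rests on a few compounds, and the source may have more. Where it says the series, first, only, none or still open, it means among the compounds named here.

Compound 1 `CCn1c(/C=C2/C(=O)Nc3ccccc32)nc2ccccc21`: 38000 nM
Compound 2 `CCn1c(/C=C2/C(=O)Nc3ccc(C)cc32)nc2ccccc21`: 38600 nM
Compound 3 `Cn1c(/C=C2/C(=O)Nc3ccc([N+](=O)[O-])cc32)nc2ccccc21`: > 50000 nM

Of the compounds shown here, three on one shared core have been tested in a functional assay on PC-3 cells (Homo sapiens) for cytotoxicity, read by MTT assay, with a stated time of 48 h; on this read-out lower numbers stand for stronger inhibition and higher numbers for weaker inhibition. Compound 1 gives 38000 nM. Compound 2, which carries a methyl in place of hydrogen on an aromatic carbon, gives 38600 nM, and the step of a 1.0-fold higher number from compound 1 to compound 2 (0.01 log units; within the scatter) shows that this small change leaves the read-out essentially unchanged. Compound 3 stands apart: its value, > 50000 nM, is a limit of the assay and not a number, as noted in the limit of > 50000 nM in this assay, at which 1 of the 3 values shown sits. So for compound 3 only a range is known, and it sits at the weaker end of what has been seen.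

Compound 4 `Cn1c(/C=C2/C(=O)Nc3ccc(Br)cc32)nc2ccccc21` is not yet measured. It differs from compound 3 in one place: bromo in place of nitro on an aromatic carbon. For the measured compounds named here, no measured step involves a swap of this kind, so the only guidance is the limit of compound 3 and the values of compounds 1 and 2, which all lie at high concentrations. A bromo compound on this core is therefore expected to land in the same weak region, with the step of an at least 1.2-fold lower number from compound 3 to compound 4 (0.09 log units; that floor lies within the scatter) expected to be small and uncertain in direction. The estimate for compound 4 is 40000 nM, with a range from 15000 nM to 120000 nM.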

Compound 4, half-maximal inhibitory concentration: > 50000 nM
Compound 4 ended at the assay's limit (the forecaster's own chance of this, stated with the estimate: 40%); middle value at least 1.2-fold (0.09 log units) away from the limit.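

In this assay compound 4 gives > 50000 nM as a limit of the assay and not a number. For the compounds shown here, compound 3 sits at the same limit, so no step between compound 3 and compound 4 can be read: the limit of > 50000 nM in this assay, at which 2 of the 4 values shown sit. The compounds shown leave open whether bromo and nitro differ at all on this shared core.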